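The source may report more compounds than this note shows. Statements on the series, on what has been measured and on what is new or still open speak of the compounds shown alone.

Measured compounds and their values:

Compound 1, `NC(=O)c1c(NC(=O)c2ccccc2Cl)sc2c1CCN(Cc1ccc([N+](=O)[O-])cc1)C2`, gives 11400 nM.
Compound 2, `Cc1ccc(C(=O)Nc2sc3c(c2C(N)=O)CCN(Cc2c(Cl)cccc2Cl)C3)cc1`, gives 10000 nM.
Compound 3, `NC(=O)c1c(NC(=O)c2ccccc2F)sc2c1CCN(Cc1ccc(Cl)cc1Cl)C2`, gives 13100 nM.

All three were tested in a functional assay on HL-60 cells (Homo sapiens) for antiproliferative activity, with a stated time of 24 h (on this read-out higher numbers stand for weaker inhibition and lower numbers for stronger inhibition), and the three numbers sit close together: compound 1 lies within the usual scatter of both compound 2 and compound 3, so nothing separates the three on this read-out.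

Compound 4, `NC(=O)c1c(NC(=O)c2ccccc2Cl)sc2c1CCN(C(=O)Nc1c(Cl)cccc1Cl)C2`, has not yet been measured. It differs from compound 1 in one place:

(2,6-dichlorophenyl)carbamoyl in place of 4-nitrobenzyl on an amine nitrogen in a ring

For the measured compounds named here, no pair of measured compounds differs in only one place, so there is no measured step to lean on. The three numbers already in hand all sit in the same region, and the change on the amine nitrogen in a ring gives no reason from these data to expect a move beyond the scatter in either direction in this assay.

Compound 4 is therefore expected to give about 12000 nM, with a range from 4000 nM to 36000 nM, meaning an expected step of a 1.1-fold higher number from compound 1 to compound 4 (0.02 log units; within the scatter).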

Compound 4, half-maximal inhibitory concentration: 17700 nM
Compound 4: middle estimate off by 1.5-fold (0.17 log units), on the low side, within the range that was stated.
By their numbers in this assay, from the lowest: compounds 2, 1, 3 and 4 (each within the scatter of the next).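

In this assay, putting (2,6-dichlorophenyl)carbamoyl in place of 4-nitrobenzyl on the amine nitrogen in a ring gives a 1.6-fold higher number from compound 1 to compound 4 (0.19 log units; within the scatter), so the two compounds cannot be told apart. For the compounds shown here, this is the first comparison here in which only one group differs, and it shows that this position can hold either of two quite different groups, one joined through a carbamoyl and bearing two chlorines and a hydrogen-bond donor, without a step beyond the scatter. No independent measurement is available to help interpret this result.

Still open, going by these compounds, is whether any group on this nitrogen can produce a step beyond the scatter, for example a bare amine carrying only hydrogen or a benzyl bearing a carboxylic acid. On these data alone, whether the same exchange gives a similar step with a different amide on the shared core also remains unknown.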